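Benzoyl to (piperidin-1-yl)carbonyl: what to expect of compound 3

The compounds below may be only part of what the source reports. "The series", "measured", "known", "first", "only" and "open" are said of these compounds alone.

- Compound 1 `CC(C)(C)c1[nH]cnc1/C=c1\[nH]c(=O)/c(=C/c2cccc(C(=O)c3ccccc3)c2)[nH]c1=O`: < 0.1 ug/mL
- Compound 2 `O=C(c1ccccc1)c1cccc(/C=c2\[nH]c(=O)/c(=C/c3ccccn3)[nH]c2=O)c1`: < 0.1 ug/mL

In a physicochemical assay for solubility, read by HPLC, with a stated time of 24 h (on this read-out lower numbers stand for lower solubility and higher numbers for higher solubility), compound 2 gives < 0.1 ug/mL, which is a limit and not a number. Compound 1 also gives only a limit. Compound 3 `O=C(c1cccc(/C=c2\[nH]c(=O)/c(=C/c3ccccn3)[nH]c2=O)c1)N1CCCCC1` differs from compound 2 in one place, with piperidin-1-yl in place of phenyl on a carbonyl carbon. For the measured compounds named here, the only measured step is a step that the two limits leave unreadable from compound 1 to compound 2, and it lies at another place on the molecule, so it offers no size to carry over. All the data stop at the same floor: the limit of < 0.1 ug/mL in this assay, at which 2 of the 2 values shown sit. A modest rise is therefore only a cautious expectation, and compound 3 may well return a limit too. The expected change is an at least 1.5-fold higher number from compound 2 to compound 3 (0.17 log units; that floor lies within the scatter). The estimate for compound 3 is 0.15 ug/mL, with an expected range from 0.05 ug/mL to 1 ug/mL.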

Compound 3, solubility: < 0.1 ug/mL
Compound 3: a limit, no number; the forecaster's own chance of this, stated with the estimate: 55%; at least 1.5-fold (0.17 log units) between middle value and limit.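

Compound 2 and compound 3 each give only a limit in this assay, so no step can be read between them. The compounds shown leave open whether any one of them truly differs from another, since all stop at one floor: the limit of < 0.1 ug/mL in this assay, at which 3 of the 3 values shown sit.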